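Swapping the halogenated aryl arm: little movement expected

The source may report more compounds than this note shows. Statements on the series, on what has been measured and on what is new or still open speak of the compounds shown alone.

Measured so far:
- compound 1 `C=CCn1c(=O)/c(=C\c2cccc(Cl)c2)[nH]c(=O)/c1=C\c1ccccc1OC`: 8900 nM
- compound 2 `C=CCn1c(=O)/c(=C\c2ccccc2Cl)[nH]c(=O)/c1=C\c1ccccc1OC`: 6400 nM
- compound 3 `C=CCn1c(=O)/c(=C\c2ccccc2C(F)(F)F)[nH]c(=O)/c1=C\c1ccccc1OC`: 9500 nM

In a functional assay on Huh-7 cells (Homo sapiens) for cytotoxicity, read by CCK-8 assay, with a stated time of 72 h (on this read-out higher numbers stand for weaker inhibition and lower numbers for stronger inhibition), compound 2 gives the lowest of the three numbers, but its steps to both neighbours lie within the scatter. Compound 4 `C=CCn1c(=O)/c(=C\c2ccc(F)c(Br)c2)[nH]c(=O)/c1=C\c1ccccc1OC` is not yet measured; it differs from compound 2 by 3-bromo-4-fluorophenyl in place of 2-chlorophenyl on a double-bonded chain carbon bound to an aromatic carbon. Among the measured compounds shown here, the steps that bear on this change all swap substituents on the same aryl arm: a 1.4-fold lower number from compound 1 to compound 2 (0.14 log units; within the scatter), a 1.5-fold higher number from compound 2 to compound 3 (0.17 log units; within the scatter) and a 1.1-fold higher number from compound 1 to compound 3 (0.03 log units; within the scatter). None of them moved the number beyond the scatter, so no step beyond the scatter is expected here either, in either direction: the expected step is a 1.3-fold higher number from compound 2 to compound 4 (0.10 log units; within the scatter). Compound 4 is therefore estimated at 8000 nM, within a range from 3500 nM to 18000 nM.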

Compound 4, half-maximal inhibitory concentration: "not active" (no number reported)
Compound 4: no number reported, so the estimate cannot be set against anything.
By their numbers in this assay, from the lowest: compounds 2, 1 and 3 (each within the scatter of the next).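

Compound 4 is reported as "not active" with no number, so its step from compound 2 cannot be read. No measurement shown bears on this result. Going by these compounds, how 3-bromo-4-fluorophenyl compares numerically with 2-chlorophenyl stays open.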